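Efficacy at the Dopamine D4 Receptor: Aryl Swap on Piperidine

This account rests on a few compounds, and the source may have more. Where it says the series, first, only, none or still open, it means among the compounds named here.

Measured compounds:
compound 1 `Cc1cccc(C(=O)NCN2CCC(c3ccccn3)CC2)c1` — 67%
compound 2 `Cc1cccc(NC(=O)CN2CCC(c3ccccc3)CC2)c1` — 37%

In a functional assay on HEK293 cells for agonist activity at D(4) dopamine receptor (Homo sapiens), read by FLIPR (on this read-out higher numbers stand for larger maximal responses and lower numbers for smaller maximal responses), compound 1 gives 67%, the highest of the two numbers measured. Its nearest neighbour, compound 2, gives 37%, a number lower by more than the scatter of this assay; as the two structures differ in more than one place, only the two values themselves are known, not a step between them.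

Compound 3 `COc1ccccc1C1CCN(CNC(=O)c2cccc(C)c2)CC1` has not yet been measured. It differs from compound 1 by 2-methoxyphenyl in place of pyridin-2-yl on a saturated ring carbon. For the measured compounds named here, no measured pair in this set isolates such a change, so there is nothing to set a direction from. Compound 1 sits well above compound 2 in this assay, and the change to compound 3 alters only the aryl group on the saturated ring carbon, so a step from compound 1 to compound 3 of modest size, in either direction, is expected. The estimate is that a number 12 percentage points lower from compound 1 to compound 3 (beyond the scatter) will stay within or just beyond the scatter. Compound 3 is expected to give about 55%, within a range from 25% to 85%.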

Compound 3, largest response reached (reported as efficacy), in percent of the reference or control that the assay uses: 55%
For compound 3 middle estimate and measured number coincide at the digits printed, and the stated range covers the measured number.
By their numbers in this assay, from the lowest: compound 2; then compound 3; then compound 1.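

The swap of pyridin-2-yl for 2-methoxyphenyl on a saturated ring carbon now has a measured size: in this assay there is a number 12 percentage points lower from compound 1 to compound 3 (beyond the scatter), a modest step. For the compounds shown here, the position therefore tolerates an aryl ring of carbon only that carries a methoxy group, and compound 3 still gives 55% on the core of compound 1. Nothing at hand accounts for the size or direction of this step.

The swap removes the ring nitrogen and adds the methoxy group in a single change, so the share of each in the step remains unresolved. The compounds shown also leave open how a plain phenyl group, or a 2-aminophenyl group, would behave at this position on the same core.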